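Compound 3 to its 4-chlorophenyl analogue

This account rests on a few compounds, and the source may have more. Where it says the series, first, only, none or still open, it means among the compounds named here.

Values in a functional assay on A549 cells (Homo sapiens) for antiproliferative activity, read by MTT assay, with a stated time of 72 h (a higher number here means a weaker inhibitor, a lower number a stronger inhibitor), as measured so far
compound 1 `O=C(CCCCCCc1nc(-c2ccccc2Cl)no1)NO` gives 8870 nM
compound 2 `O=C(CCCCCCc1nc(-c2cccs2)no1)NO` gives 4370 nM
compound 3 `Nc1ccccc1NC(=O)CCCCCCc1nc(-c2ccccc2)no1` gives 23900 nM

Compound 3 has the highest number of the three in this assay and lies beyond the scatter from both compound 1 and compound 2. The next compound is compound 4 `Nc1ccccc1NC(=O)CCCCCCc1nc(-c2ccc(Cl)cc2)no1` with chloro in place of hydrogen on an aromatic carbon, para to a large group, as counted here: chloro in place of hydrogen on an aromatic carbon and nothing else changed. Going by the values given here, the only measured step at this aromatic end is a 2.0-fold lower number from compound 1 to compound 2 (0.31 log units; beyond the scatter) and it is a modest one. Among the compounds with values here, that step exchanges whole aromatic groups, so it bears only loosely, and no measured pair shows chloro replacing hydrogen. A modest change is therefore expected, leaning slightly towards a lower number, though a result within the scatter would be no surprise. The estimate means an expected 1.3-fold lower number from compound 3 to compound 4 (0.12 log units; within the scatter) in this assay and no larger move. Compound 4 is estimated at 18000 nM with an expected range from 8000 nM to 40000 nM as its span.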

Compound 4, half-maximal inhibitory concentration: 13800 nM
Beside the measured number, compound 4's estimate is 1.3-fold (0.12 log units) above it; the measured number falls inside the stated range.
By their numbers in this assay, from the lowest: compound 2; then compounds 1, 4 and 3 (each within the scatter of the next, the first and the last beyond it).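

In this assay, going by these compounds alone, the pair gives the first reading of a single substitution on this aromatic ring: chloro in place of hydrogen, para to a large group, gives a 1.7-fold lower number from compound 3 to compound 4 (0.24 log units; within the scatter) and so stays short of a resolved change. This place on the six-membered aromatic ring therefore accepts one chlorine atom with no step beyond the scatter, at least on the core of compound 3. The earlier step swapped whole aromatic groups and could not isolate this one atom. No available data bear on the reason for this result.

From the compounds shown here alone, it remains open whether a methoxy group or a carboxylic acid at this same place would give a step beyond the scatter. Also open, going by these compounds, is whether the same chloro change would read alike on the core of compound 2, which carries the hydroxamic acid end.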